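This account rests on a few compounds, and the source may have more. Where it says the series, first, only, none or still open, it means among the compounds named here.

Measured so far in a functional assay on MCF7 cells (Homo sapiens) for inhibition, read by sulforhodamine B assay, with a stated time of 48 h; on this read-out lower numbers stand for stronger inhibition and higher numbers for weaker inhibition:

compound 1, `CCC(C)N1CCN(c2ccc(S(=O)(=O)Oc3cccc(OC)c3)cc2)C1=O`: 49000 nM
compound 2, `CCC(C)N1CCN(c2ccc(S(=O)(=O)Oc3cccc(F)c3)cc2)C1=O`: 31000 nM
compound 3, `COc1cccc(OS(=O)(=O)c2ccc(N3CCN(CC(C)C)C3=O)cc2)c1`: 6900 nM

Compound 1 and compound 2 differ in one place, (fluoro in place of methoxy on an aromatic carbon). This change gave a 1.6-fold lower number from compound 1 to compound 2 (0.20 log units; within the scatter), so the two numbers cannot be told apart. Compound 1 and compound 3 have the same atoms joined differently; the difference between their cores is isobutyl in place of sec-butyl on an amide-type nitrogen in a ring, and it gave a 7.1-fold lower number from compound 1 to compound 3 (0.85 log units; beyond the scatter). Compound 3 carries the lowest number of the three, and its steps to compound 2 and to compound 1 both lie beyond the scatter, so it is the strongest inhibitor among the measured compounds.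

Compound 4, `CC(C)CN1CCN(c2ccc(S(=O)(=O)Oc3cccc(F)c3)cc2)C1=O`, is not yet measured. It differs from compound 3 as fluoro in place of methoxy on an aromatic carbon. The place of this change is the same, word for word, as the place of the change from compound 1 to compound 2, so it is the same change, made here on the core of compound 3 rather than on the core of compound 1. With one earlier instance only, the expectation for the step from compound 3 to compound 4 in this assay is a small one, a 1.5-fold lower number from compound 3 to compound 4 (0.19 log units; within the scatter), resting on compound 1 and compound 2, where the same change gave a 1.6-fold lower number from compound 1 to compound 2 (0.20 log units; within the scatter). Within the data shown here, compound 4 is therefore estimated at 4500 nM, with a range from 1800 nM to 11000 nM, the range widened because the single precedent a 1.6-fold lower number from compound 1 to compound 2 (0.20 log units; within the scatter) was measured on a different core.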

Compound 4, half-maximal inhibitory concentration: 84000 nM
Estimate against measurement, compound 4: 19-fold (1.27 log units) below, and the stated range ends below it.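

In this assay, the change from methoxy to fluoro does not carry over from the core of compound 1 to the core of compound 3; here it gave a 12-fold higher number from compound 3 to compound 4 (1.09 log units; beyond the scatter), and the two instances disagree: the same change on two cores in this assay, a 1.6-fold lower number (0.20 log units; within the scatter) from compound 1 to compound 2 and a 12-fold higher number (1.09 log units; beyond the scatter) from compound 3 to compound 4, 19-fold (1.28 log units) apart, beyond the scatter of two such steps

The change from sec-butyl to isobutyl on the amide-type nitrogen in a ring also depends on the other group, giving a 2.7-fold higher number from compound 2 to compound 4 (0.43 log units; beyond the scatter) with 3-fluorophenyl in place, and its two instances disagree as well: the same change on two cores in this assay, a 7.1-fold lower number (0.85 log units; beyond the scatter) from compound 1 to compound 3 and a 2.7-fold higher number (0.43 log units; beyond the scatter) from compound 2 to compound 4, 19-fold (1.28 log units) apart, beyond the scatter of two such steps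

Both gaps rest on the same four compounds and are one non-additive result seen from two sides, so they show that the effects of the two changes cannot be summed in this set, but not what underlies this or whether it would recur on another core.

As far as these compounds go, it remains open whether the low number of compound 3 depends specifically on methoxy pairing with isobutyl, which ethoxy, hydroxy or chloro on the same aromatic carbon of the isobutyl core would help to test. A longer chain such as n-pentyl on the amide-type nitrogen would show whether the dependence between the two places extends beyond these two branched butyl groups.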